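The compounds below may be only part of what the source reports. "The series", "measured", "known", "first", "only" and "open" are said of these compounds alone.

Notes on the series. Three compounds have numbers in an ADME assay on cells for inhibition of cytochrome P450 11B1, mitochondrial (Homo sapiens), read by HTRF; on this read-out higher numbers stand for weaker inhibition and lower numbers for stronger inhibition. Compound 1 `CCC1c2cc(Cl)ccc2C(=O)N1c1cccnc1` gives 3340 nM in this assay. Compound 2 `CS(=O)(=O)N[C@@H]1CCCc2c1cncc2N1CCc2cc(Cl)ccc2C1=O` gives 5150 nM in this assay, and compound 3 `CS(=O)(=O)N[C@@H]1CCCc2c1cncc2N1Cc2cc(Cl)ccc2C1=O` gives 9350 nM in this assay. Compound 1 thus carries the lowest number of the three; its gap to compound 2 lies within the scatter of repeated measurements, so those two cannot be ordered, while its gap to compound 3 lies beyond the scatter. Among the compounds with values here, no two of the measured compounds differ in a single place, so no single-point step has a measured size in this assay.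

Compound 4 `O=C1c2ccc(Cl)cc2CN1c1cccnc1` has not yet been measured. It differs from compound 1 by hydrogen in place of ethyl on a saturated ring carbon. Within the data shown here, no measured pair shows the effect of this change in this assay; the expectation rests on the change alone, a loss of the ethyl group with no change in donors, acceptors or charge. Compound 4 is expected to show weaker inhibition, with an estimated 10000 nM and a likely range from 3500 nM to 30000 nM. The estimated step of a 3.0-fold higher number from compound 1 to compound 4 (0.48 log units; beyond the scatter) is expected to run toward higher numbers and to exceed the scatter, but only moderately.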

Compound 4, half-maximal inhibitory concentration: 10700 nM
Compound 4: the middle estimate sits 1.1-fold (0.03 log units) below what was measured; the measured number falls inside the stated range.
By their numbers in this assay, from the lowest: compounds 1, 2, 3 and 4 (each within the scatter of the next, the first and the last beyond it).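

Within the data shown here, the pair gives the first measured single-point step in this assay: with hydrogen in place of ethyl on the saturated ring carbon, the result is a 3.2-fold higher number from compound 1 to compound 4 (0.51 log units; beyond the scatter). The step is modest, but it lies beyond the scatter, so this carbon is not indifferent to what it carries, and on the core of compound 1 the ethyl group goes with stronger inhibition. Nothing available explains the size or direction of this step.

With only hydrogen and ethyl compared at this carbon, a single pair cannot show whether the number keeps falling as the substituent grows, or whether a methyl group, a longer chain such as propyl, or a ring such as cyclopropyl would give a lower or a higher number than ethyl. From the compounds shown here alone, it also remains open whether a hydroxyl group or an amine at the same carbon would be accepted as well as ethyl, and whether the step seen here would carry over to another core.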